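A few compounds are considered here, and "the series" means these few. Any claim that something is new, unique, unknown or untested is made for them only; others in the source may bear on it.

Measured compounds:
compound 1, `COc1cc(-c2cc(/C=C/C(=O)c3ccc(Cl)c(Cl)c3)[nH]n2)cc(OC)c1OC`, 94% in a functional assay on OVCAR-8 cells (Homo sapiens) for cytotoxicity, read by sulforhodamine B assay, with a stated time of 48 h, tested at 0.01 uM; on this read-out higher numbers stand for a weaker effect at the one concentration tested and lower numbers for a stronger effect
compound 2, `COc1ccc(-c2cc(/C=C/C(=O)c3cc(OC)c(OC)c(OC)c3)[nH]n2)cc1OC`, 100% in this assay

Of the compounds shown here, two have been measured in this assay. Compound 1 gives 94%, the lower of the two numbers, and compound 2 gives 100%; the gap between them lies within the usual scatter, so the two cannot be told apart on these numbers, and both sit near the top of the scale, which at the single concentration used means only a weak effect for either.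

Compound 3, `COc1ccc(C(=O)/C=C/c2cc(-c3cc(OC)c(OC)c(OC)c3)n[nH]2)cc1OC`, has not been measured yet. It differs from compound 1 in one place: 3,4-dimethoxyphenyl in place of 3,4-dichlorophenyl on a carbonyl carbon. Among the measured compounds shown here, no measured pair shows the effect of this particular change, so any expectation rests on the two numbers at hand, which are close to one another and to the top of the range. The step from compound 1 to compound 3 is expected to be small, about a number 2 percentage points higher from compound 1 to compound 3 (within the scatter), and not beyond the scatter in either direction. Compound 3 is therefore estimated to give 96%, with a likely range from 86% to 104%.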

Compound 3, a percentage reported as activity, at one concentration (the size of the read-out at that concentration, not a potency): 97%
Beside the measured number, compound 3's estimate is 1 percentage points below it; measured number inside the range.
By their numbers in this assay, from the lowest: compounds 1, 3 and 2 (each within the scatter of the next).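

In this assay, among the compounds shown here, 3,4-dimethoxyphenyl in place of 3,4-dichlorophenyl on a carbonyl carbon gives a number 3 percentage points higher from compound 1 to compound 3 (within the scatter), the first reading of a change in this one place, as compound 1 and compound 2 differ in more than one place. The exchange replaces a group of 8 heavy atoms with 0 hydrogen-bond acceptors by one of 10 heavy atoms with 2 hydrogen-bond acceptors, yet at the single concentration tested this read-out does not tell compound 1 and compound 3 apart, and both sit near the top of the scale, where the effect is weak. Nothing available here bears on why these two compounds read alike.

On these data alone, it remains open whether a phenyl group carrying an amine or a carboxylic acid, or a longer chain on this carbonyl carbon, would give a number beyond the scatter of those seen so far. As far as these compounds go, it is also open whether compound 1 and compound 3 would separate at a higher concentration than the one used here.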